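The source may report more compounds than this note shows. Statements on the series, on what has been measured and on what is new or still open speak of the compounds shown alone.

Compounds measured in a functional assay on SW-620 cells (Homo sapiens) for cytotoxicity, read by colorimetric assay; a higher number here means a weaker inhibitor, a lower number a stronger inhibitor:
Compound 1 `O=C(/C=C/c1ccc(CN2C(=O)/C(=C3\Nc4ccccc4\C3=N/O)c3cccc(Cl)c32)cc1)NO`: 60 nM
Compound 2 `COc1ccc2c(c1)/C(=C1/Nc3ccccc3/C1=N\O)C(=O)N2Cc1ccc(/C=C/C(=O)NO)cc1`: 40 nM
Compound 3 `COc1ccc2c(c1)/C(=C1/Nc3ccccc3/C1=N\O)C(=O)N2Cc1ccc(C(=O)NO)cc1`: 40 nM

Among the compounds with values here, compound 2 stands level with compound 3, and all three numbers in this assay lie within the usual scatter of repeated measurements, so no compound here can be ranked above another.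

The next compound to consider is compound 4 `O=C(/C=C/c1ccc(CN2C(=O)/C(=C3\Nc4ccccc4\C3=N/O)c3ccccc32)cc1)NO`, which has hydrogen in place of methoxy on an aromatic carbon of compound 2 (hydrogen in place of methoxy on an aromatic carbon). Within the data shown here, no measured pair isolates this change. Among the measured compounds shown here, the only measured step, no change at the digits printed from compound 2 to compound 3 (within the scatter), replaces 2-(hydroxycarbamoyl)ethenyl with hydroxycarbamoyl and leaves the methoxy untouched, so it bears on the question only indirectly. It does show that the number held steady through that change elsewhere in the molecule. Compound 1 also carries no methoxy, and its 60 nM lies within the scatter of the value for compound 2. That gives a modest reason to expect little movement on losing the methoxy, though compound 1 differs in other ways too.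

The estimated change is a 1.3-fold higher number from compound 2 to compound 4 (0.10 log units; within the scatter), and nothing beyond the scatter is expected. For compound 4 the expected value is 50 nM, with an estimated range of 20 nM to 120 nM.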

Compound 4, half-maximal inhibitory concentration: 50 nM
Compound 4: the middle estimate sits on the measured number at the digits printed; low and high end bracket the measured number.
By their numbers in this assay, from the lowest: compounds 2, 3, 4 and 1 (each within the scatter of the next).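

Replacing methoxy with hydrogen gives a 1.3-fold higher number from compound 2 to compound 4 (0.10 log units; within the scatter) in this assay, so this change now has a measured pair of its own, and it stays within the scatter. Compound 4 also pairs with compound 1, where hydrogen in place of chloro gives a 1.2-fold lower number from compound 1 to compound 4 (0.08 log units; within the scatter), again within the scatter, so in this assay neither methoxy nor chloro can be told apart from plain hydrogen at the carbon each occupies. No measurement at hand offers an explanation for these results.

Going by these compounds, only hydrogen, methoxy and chloro appear on this ring, so it remains open whether an amine, a carboxylic acid or a longer chain such as butoxy would also leave the number within the scatter. The swap of 2-(hydroxycarbamoyl)ethenyl for hydroxycarbamoyl is also shown only with methoxy on the ring, so it remains open whether the number would hold in the same way for that swap with hydrogen or chloro there instead.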